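A few compounds are considered here, and "the series" means these few. Any claim that something is new, unique, unknown or untested is made for them only; others in the source may bear on it.

Compound 1 `CCC(=O)NC(c1ccco1)c1cc(Cl)c2cccnc2c1O` gives the lowest of the two numbers in an assay for inhibition of Polyunsaturated fatty acid lipoxygenase ALOX12 (Homo sapiens), read by spectrophotometry (on this read-out higher numbers stand for weaker inhibition and lower numbers for stronger inhibition), where compound 1 reads 1000 nM. Compound 2 `CCC(=O)NC(c1ccco1)c1cc(Br)c2cccnc2c1O` stands nearest; in this assay compound 2 reads 2000 nM, and the step of a 2.0-fold higher number from compound 1 to compound 2 (0.30 log units; within the scatter) lies within the scatter. Compound 3 `CCC(=O)NC(c1ccc(F)cc1)c1cc(Cl)c2cccnc2c1O` differs from compound 1 by 4-fluorophenyl in place of furan-2-yl on a saturated chain carbon bound to an amide-type nitrogen and an aromatic carbon. Within the data shown here, no measured step touches this kind of change, so nothing here supports a shift beyond the scatter in either direction. Compound 3 is therefore expected to give 1200 nM in this assay, with a range of 300 nM to 5000 nM. The expected step from compound 1 to compound 3 is a 1.2-fold higher number from compound 1 to compound 3 (0.08 log units; within the scatter).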

Compound 3, half-maximal inhibitory concentration: > 50000 nM
Compound 3: a limit, no number; the forecaster's own chance of this, stated with the estimate: 10%; at least 41-fold (1.61 log units) between middle value and limit.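

Among these compounds, at the saturated chain carbon bound to an amide-type nitrogen and an aromatic carbon, the change from furan-2-yl to 4-fluorophenyl gives a large step (an at least 50-fold higher number from compound 1 to compound 3 (1.69 log units; beyond the scatter)), whereas the one earlier step, bromo in place of chloro on an aromatic carbon, stayed within the scatter. Among the compounds shown here, this position therefore tolerates far less change than the earlier compounds could show. The reading for compound 3 is a limit of the assay and not a number: the limit of > 50000 nM in this assay, at which 1 of the 3 values shown sits.

The compounds shown leave open whether the fluorine or the six-membered ring accounts for the step, since plain phenyl is not among them. They also leave open whether thiophen-2-yl at this position would keep the reading of compound 1.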